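Working notes: from compound 3 to compound 4

This account rests on a few compounds, and the source may have more. Where it says the series, first, only, none or still open, it means among the compounds named here.

Values so far in a physicochemical assay for solubility, in phosphate buffer, with a stated time of 18 h; on this read-out higher numbers stand for higher solubility and lower numbers for lower solubility
compound 1 `CCCCc1nc(C(C)(C)C)nc2nc(N)c(C#N)c(N)c12` gives 6000 nM
compound 2 `CC(C)(C)c1nc(CCCCC#N)c2c(N)c(C#N)c(N)nc2n1` gives 16000 nM
compound 3 `CC(C)(C)c1nc(-c2cnccn2)c2c(N)c(C#N)c(N)nc2n1` gives 86000 nM
compound 4 `CC(C)(C)c1nc(-c2ncc[nH]2)c2c(N)c(C#N)c(N)nc2n1` is not yet measured

Compound 3 stands highest of the three (86000 nM). The change to compound 4 is 1H-imidazol-2-yl in place of pyrazin-2-yl on an aromatic carbon. Going by the values given here, no measured step exchanges one aromatic ring for another. The nearest evidence is pyrazin-2-yl replacing butyl (a 14-fold higher number from compound 1 to compound 3 (1.16 log units; beyond the scatter)) and replacing 4-cyanobutyl (a 5.4-fold higher number from compound 2 to compound 3 (0.73 log units; beyond the scatter)). Both start from a chain, so neither sets a direction here. The expected change, no step beyond the scatter in this assay is a 1.4-fold lower number from compound 3 to compound 4 (0.16 log units; within the scatter) with wide uncertainty. Compound 4 is expected at 60000 nM (estimated range 15000 nM to 200000 nM).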

Compound 4, solubility: < 1000 nM
Compound 4: only a limit was reported; the forecaster's own chance of this, stated with the estimate: 10%; middle value at least 60-fold (1.77 log units) from the limit.
By their numbers in this assay, from the lowest: compound 1; then compound 2; then compound 3. At a limit, below all of these: compound 4.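

For compound 4 the read-out in this assay is a limit and not a number: the limit of < 1000 nM in this assay, at which 1 of the 4 values shown sits. This aromatic carbon, opposite the ring nitrogen, is sensitive to which aromatic ring it carries, with an at least 86-fold lower number from compound 3 to compound 4 (1.93 log units; beyond the scatter) for 1H-imidazol-2-yl in place of pyrazin-2-yl. An aromatic ring here therefore does not by itself give the higher number, as compound 3 does against the chains, since both chain compounds also stand clear of the limit, with an at least 16-fold lower number from compound 2 to compound 4 (1.20 log units; beyond the scatter) and an at least 6.0-fold lower number from compound 1 to compound 4 (0.77 log units; beyond the scatter).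

The compounds shown do not separate the five-membered ring from its hydrogen-bond donor as the feature that goes with the limit. A methyl group on the imidazole nitrogen or a pyridine ring at this carbon would bear on that question.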